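Trading an Acetyl for Hydrogen in a Cytotoxicity Series

The source may hold more compounds than are shown below. What is called first, only, known or untested is meant among the compounds shown, and "the series" means these compounds.

Compound 1 has the structure `COc1ccc(C2=C(c3cc(OC)c(OC)c(OC)c3)C(=O)C(OC(C)=O)C2)cc1Cl`. In an ADME assay on L132 cells (Homo sapiens) for cytotoxicity, read by MTT assay, with a stated time of 72 h (on this read-out lower numbers stand for stronger inhibition and higher numbers for weaker inhibition), compound 1 gives < 1 ug/mL, which is a limit of the assay rather than a measured number (the limit of < 1 ug/mL in this assay, at which 1 of the 2 values shown sits). Compound 2, `COc1ccc(C2=C(c3cc(OC)c(OC)c(OC)c3)C(=O)C(OC(C)=O)C2)cc1OC(C)C`, differs from compound 1 by isopropoxy in place of chloro on an aromatic carbon. In this assay compound 2 gives > 100 ug/mL, again a limit of the assay (the limit of > 100 ug/mL in this assay, at which 1 of the 2 values shown sits). Between these two there is an at least 100-fold higher number from compound 1 to compound 2 (2.00 log units; beyond the scatter). Compound 3, `COc1ccc(C2=C(c3cc(OC)c(OC)c(OC)c3)C(=O)C(O)C2)cc1Cl`, has not yet been measured; it differs from compound 1 by hydrogen in place of acetyl on an oxygen on a saturated carbon, which reads, one bond further out, as acetoxy to hydroxy. Going by the values given here, the single measured step concerns a different position on the shared core, so it offers no direct guide to this change. The expected step is an at least 1.5-fold higher number from compound 1 to compound 3 (0.17 log units; that floor lies within the scatter), likely within the scatter. The estimate for compound 3 is 1.5 ug/mL, in the range 0.3 ug/mL to 8 ug/mL.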

Compound 3, half-maximal inhibitory concentration: < 1 ug/mL
Compound 3 ended at the assay's limit; the forecaster's own chance of this, stated with the estimate: 30%; at least 1.5-fold (0.17 log units) between middle value and limit.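

Compound 1 and compound 3 both end at the same limit of this assay, so the step between them cannot be read: the limit of < 1 ug/mL in this assay, at which 2 of the 3 values shown sit.

The compounds shown leave open whether going from acetoxy to hydroxy changes the result at all, and in which direction.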